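The compounds below may be only part of what the source reports. "The series", "measured", "known", "first", "only" and "open" are said of these compounds alone.

Series notes. Three members of this series have been measured in an assay on isolated protein for inhibition of N-acylethanolamine-hydrolyzing acid amidase (Homo sapiens), read by fluorescence, with a stated time of 90 min; on this read-out lower numbers stand for stronger inhibition and higher numbers for weaker inhibition. Compound 1 `N#CN1CC(OCc2ccc(-c3ccc(F)cc3)cc2)C1` gives 0.68 nM; compound 2 `COc1ccncc1-c1ccc(COC2CN(C#N)C2)cc1` gives 40 nM; compound 3 `N#CN1CC(OCc2ccc(Oc3ccccc3)cc2Br)C1` gives 1.03 nM. On the numbers shown, compound 3 stands second highest of the three, but its gap to compound 1 lies within the usual scatter, so the two read as equivalent; only compound 2 sits clearly apart, on the weaker side, beyond the scatter.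

Compound 4 `COc1ccccc1-c1cc(Oc2ccccc2)ccc1COC1CN(C#N)C1` is the next member, not yet measured. Against compound 3 the change is 2-methoxyphenyl in place of bromo on an aromatic carbon. Among the compounds with values here, no measured pair shows this change, so no step can be quoted for it. Within the data shown here, the one member with a methoxy-bearing aromatic ring attached to the shared core, compound 2, reads weak at 40 nM, though its substitution pattern differs from that of compound 4, and compound 3 retains the phenoxy group that goes with 1.03 nM. A modest loss is expected, a 2.4-fold higher number from compound 3 to compound 4 (0.39 log units; beyond the scatter), but none beyond the scatter cannot be excluded. Compound 4 is estimated at 2.5 nM, with a range from 0.6 nM to 12 nM.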

Compound 4, half-maximal inhibitory concentration: 23.7 nM
The estimate for compound 4 lay 9.5-fold (0.98 log units) below the measured number; the measured number lies above the stated range.
By their numbers in this assay, from the lowest: compounds 1 and 3 (each within the scatter of the next); then compounds 4 and 2 (each within the scatter of the next).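

In this assay, the series now has its first readable step: 2-methoxyphenyl in place of bromo on this aromatic carbon gives a 23-fold higher number from compound 3 to compound 4 (1.36 log units; beyond the scatter), a large change beyond the scatter. The two groups are therefore not interchangeable at this position, ortho to a group of 8 heavy atoms and meta to a phenoxy group, and keeping the phenoxy group does not hold the number near that of compound 3. The compounds shown offer nothing that accounts for this step.

Going by these compounds, it remains open whether the methoxy group or the aromatic ring that carries it goes with the higher number, which an unsubstituted phenyl at this position would separate. A methyl group or a chlorine here would show how the position responds to substituents much closer to bromo in atom count.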